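Swapping the amide for a free acid on the shared core

The source may report more compounds than this note shows. Statements on the series, on what has been measured and on what is new or still open speak of the compounds shown alone.

Of the compounds shown here, three built on one shared core have been tested in a functional assay for inhibition of nuclear factor NF-kappa-B complex (Homo sapiens); a lower number here means a stronger inhibitor, a higher number a weaker inhibitor. Compound 1 `COc1ccc2c(c1)OC(c1cc(OC)c(OC)c(OC)c1)C(C(=O)NC(C)(C)C)=C2` carries a tert-butyl amide and gives 28400 nM. Compound 2 `COc1ccc2c(c1)OC(c1cc(OC)c(OC)c(OC)c1)C(C(=O)OC(C)C)=C2` carries an isopropyl ester instead and gives 11800 nM. Compound 3 `CCCCNC(=O)C1=Cc2ccc(OC)cc2OC1c1cc(OC)c(OC)c(OC)c1` carries a butyl amide and gives 25500 nM. Among these three numbers compound 3 stands second highest: its number and that of compound 1 lie within the usual scatter of each other, while the step of a 2.2-fold higher number from compound 2 to compound 3 (0.33 log units; beyond the scatter) is modest but beyond the scatter.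

Compound 4 `COc1ccc2c(c1)OC(c1cc(OC)c(OC)c(OC)c1)C(C(=O)O)=C2` differs from compound 3 by hydroxy in place of butylamino on a carbonyl carbon. The measured steps that touch the same carbonyl are a 2.4-fold lower number from compound 1 to compound 2 (0.38 log units; beyond the scatter) and a 2.2-fold higher number from compound 2 to compound 3 (0.33 log units; beyond the scatter), both modest, while a 1.1-fold lower number from compound 1 to compound 3 (0.05 log units; within the scatter) lies within the scatter. Within the data shown here, none of them replaces the group with a free hydroxy, so there is no direct precedent, and a step of modest size at most is expected in this assay, its direction uncertain. The estimate for compound 4 is therefore 35000 nM, with a range from 12000 nM to 100000 nM. That estimate corresponds to an expected step of a 1.4-fold higher number from compound 3 to compound 4 (0.14 log units; within the scatter).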

Compound 4, half-maximal inhibitory concentration: > 50000 nM
Compound 4: only a limit was reported (the forecaster's own chance of this, stated with the estimate: 15%); at least 1.4-fold (0.15 log units) between middle value and limit.
By their numbers in this assay, from the lowest: compound 2; then compounds 3 and 1 (each within the scatter of the next). At a limit, above all of these: compound 4.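

Compound 4 replaces the amide or ester group on the carbonyl carbon with a free hydroxy, giving a carboxy group, and its result in this assay is a limit rather than a number: the limit of > 50000 nM in this assay, at which 1 of the 4 values shown sits. Set against the isopropyl ester, the change gives an at least 4.2-fold higher number from compound 2 to compound 4 (0.62 log units; beyond the scatter), a floor larger than any earlier step at this carbonyl, so here losing the isopropyl clearly weakens inhibition. The floors against the two amides, an at least 1.9-fold higher number from compound 3 to compound 4 (0.29 log units; that floor lies within the scatter) and an at least 1.7-fold higher number from compound 1 to compound 4 (0.24 log units; that floor lies within the scatter), lie within the scatter, so these steps alone do not separate the acid from the amides.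

As far as these compounds go, how far compound 4 lies beyond its limit remains open. Also open, from the compounds shown here alone, is how a primary amide, or an ester with a longer chain, would behave on the same carbonyl.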